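The source may hold more compounds than are shown below. What is called first, only, known or untested is meant among the compounds shown, and "the series" means these compounds.

Measured so far:
- compound 1 `N#Cc1ccc(/C=N/Nc2nc(N)c3ncn([C@@H]4O[C@H](CO)[C@@H](O)[C@H]4O)c3n2)cc1`: 4.1 nM
- compound 2 `CCCCC/C=C/C=C/C=N/Nc1nc(N)c2ncn([C@@H]3O[C@H](CO)[C@@H](O)[C@H]3O)c2n1`: 2 nM
- compound 3 `COc1ccc(/C=N/Nc2nc(N)c3ncn([C@@H]4O[C@H](CO)[C@@H](O)[C@H]4O)c3n2)cn1`: 2.6 nM

All three compounds share the same core and differ only in the group attached to the carbon that carries a double bond to nitrogen. In an assay on CHO-K1 cells for displacement of a labelled ligand from adenosine receptor A1 (Homo sapiens), read by scintillation counting, with a stated time of 60 min (a higher number here means a weaker inhibitor, a lower number a stronger inhibitor), compound 1 has the highest of the three numbers, but the spread is small: the change to the chain gives a 2.1-fold lower number from compound 1 to compound 2 (0.31 log units; beyond the scatter), while the change to the methoxypyridinyl ring gives a 1.6-fold lower number from compound 1 to compound 3 (0.20 log units; within the scatter). Between the chain and the methoxypyridinyl ring there is a 1.3-fold higher number from compound 2 to compound 3 (0.11 log units; within the scatter). Taken together, quite different groups at this position give numbers close to one another.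

Among the compounds with values here, compound 4 `Nc1nc(N/N=C/c2ccc(OCc3ccc(F)cc3)cc2)nc2c1ncn2[C@@H]1O[C@H](CO)[C@@H](O)[C@H]1O` keeps the six-membered aromatic ring of carbon only that compound 1 carries and changes only its substituent: (4-fluorobenzyl)oxy in place of cyano on an aromatic carbon. Within the data shown here, no measured step varies a substituent on this ring, so the closest guides are the whole-group swaps from compound 1, which stayed within or just beyond the scatter. The expectation is therefore a step of a 1.2-fold higher number from compound 1 to compound 4 (0.09 log units; within the scatter), which is not expected to exceed the scatter. Compound 4 is estimated at 5 nM, with a likely range from 1.5 nM to 20 nM.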

Compound 4, inhibition constant: 70 nM
Beside the measured number, compound 4's estimate is 14-fold (1.15 log units) below it, and the stated range ends below it.
By their numbers in this assay, from the lowest: compounds 2, 3 and 1 (each within the scatter of the next, the first and the last beyond it); then compound 4.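

In this assay, within the data shown here, replacing cyano with (4-fluorobenzyl)oxy on the aromatic ring gives a 17-fold higher number from compound 1 to compound 4 (1.23 log units; beyond the scatter), the first large step in this set, so the tolerance seen among compounds 1, 2 and 3 does not extend to every group at this end of the molecule. The change brings in a second six-membered aromatic ring and adds heavy atoms to the substituent, while the counts of hydrogen-bond donors and acceptors and the net charge stay the same, so those counts do not separate compound 1 from compound 4. Nothing measured here accounts for the large step.

The compounds shown leave open which part of the new group goes with the higher number: the fluorine, the second ring or the oxygen link. A plain benzyloxy group without fluorine, or a small methoxy group on the same ring, would help to separate these parts and show whether the step comes from the whole group or from one piece of it.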